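This account rests on a few compounds, and the source may have more. Where it says the series, first, only, none or still open, it means among the compounds named here.

Measured in a functional assay on HCT-116 cells (Homo sapiens) for cytotoxicity, read by crystal violet staining, with a stated time of 7 days; a higher number here means a weaker inhibitor, a lower number a stronger inhibitor:
- compound 1 `COc1ccc(/C=C/C(=O)C2=Cc3cc(OC)ccc3OC2)cc1`: 590 nM
- compound 2 `COc1cc(OC)cc(C(=O)/C=C/C2=Cc3cc(Br)ccc3OC2)c1`: 3400 nM

Compound 1 holds the lower of the two numbers, and the gap up to compound 2 lies beyond the usual scatter. These two compounds differ in more than one place, so their gap says nothing about any single change.

Not yet measured is compound 3 `COc1ccc2c(c1)C=C(C(=O)/C=C/c1ccccc1OC)CO2`, which carries 2-methoxyphenyl in place of 4-methoxyphenyl on a double-bonded chain carbon bound to a double-bonded chain carbon. Among the compounds with values here, no measured pair covers this change, so the expectation is weakly grounded. A modest move towards a higher number is expected in this assay, with the estimate being a 1.5-fold higher number from compound 1 to compound 3 (0.18 log units; within the scatter). A result within the scatter of compound 1 would not be surprising.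

For compound 3 the estimated value is 900 nM, with an expected range from 250 nM to 3500 nM.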

Compound 3, half-maximal inhibitory concentration: 1620 nM
Beside the measured number, compound 3's estimate is 1.8-fold (0.26 log units) below it, within the range that was stated.
By their numbers in this assay, from the lowest: compound 1; then compound 3; then compound 2.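

In this assay, within the data shown here, 2-methoxyphenyl in place of 4-methoxyphenyl on a double-bonded chain carbon bound to a double-bonded chain carbon gives a 2.7-fold higher number from compound 1 to compound 3 (0.44 log units; beyond the scatter), the only single-place step so far. The two groups have the same atoms and the same counts, so this position responds to how the group is arranged and not only to which atoms it holds, and of the two arrangements 4-methoxyphenyl gives the lower number. No measurement is available that would explain the step.

As far as these compounds go, only these two groups are compared at this position, so it remains open how an unsubstituted phenyl or a phenyl carrying an amine would behave there. From the compounds shown here alone, compound 2 differs from compound 1 and compound 3 in more than one place, so the effect of its bromine on the shared core also remains open.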